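Swapping two chlorines for two methyls on a benzophenone

A few compounds are considered here, and "the series" means these few. Any claim that something is new, unique, unknown or untested is made for them only; others in the source may bear on it.

Of the compounds shown here, three sharing one core have been measured in a physicochemical assay for solubility; a lower number here means a less soluble compound, a higher number a more soluble compound. Compound 1, `Cc1cc(C)cc(Cc2cc(Br)ccc2OCCn2ccc(=O)[nH]c2=O)c1`, gives 1700 nM. Compound 2, `Cc1cccc(Cc2cc(C)ccc2OCCn2ccc(=O)[nH]c2=O)c1`, gives 199000 nM. Compound 3, `O=C(c1cc(Cl)cc(Cl)c1)c1cc(Cl)ccc1OCCn1ccc(=O)[nH]c1=O`, gives 9400 nM, which places it second highest of the three: compound 1 sits a good way below it, beyond the usual scatter, while compound 2 sits far above it, also beyond the scatter. Among the compounds with values here, none of these three differs from another in a single place, so no clean step between measured compounds can be read off.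

Compound 4, `Cc1cc(C)cc(C(=O)c2cc(Cl)ccc2OCCn2ccc(=O)[nH]c2=O)c1`, is the next compound to be tested in this assay. It differs from compound 3 in one place: 3,5-dimethylphenyl in place of 3,5-dichlorophenyl on a carbonyl carbon. Within the data shown here, nothing measured so far isolates this exchange, so any expectation rests on the three values shown. The step from compound 3 to compound 4 is expected to be small and, if anything, upward, within or barely beyond the scatter, giving a 1.6-fold higher number from compound 3 to compound 4 (0.20 log units; within the scatter). On that basis compound 4 is estimated at 15000 nM, with a plausible range from 5000 nM to 45000 nM in this assay.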

Compound 4, solubility: 16600 nM
Beside the measured number, compound 4's estimate is 1.1-fold (0.04 log units) below it; measured number inside the range.
By their numbers in this assay, from the lowest: compound 1; then compounds 3 and 4 (each within the scatter of the next); then compound 2.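

In this assay, within the data shown here, the exchange of 3,5-dichlorophenyl for 3,5-dimethylphenyl on a carbonyl carbon gives a 1.8-fold higher number from compound 3 to compound 4 (0.25 log units; within the scatter), and it is the first step here that isolates a change in a single place. At this position, two groups with the same count of heavy atoms and the same six-membered aromatic ring of carbon only, differing in that two chlorine atoms give way to carbon, cannot be told apart in this read-out, so this exchange does not register beyond the ordinary spread of repeat measurements. No accompanying measurement bears on this result, so the data offer no explanation for it.

Compounds 1 and 2 each differ from compounds 3 and 4 in more than one place, so the step does not show how much the carbonyl carbon or the other ring substituents contribute to the wide spread of values in the series. It also leaves open whether this position would respond to a group of a different kind, such as a pyridine ring or a phenyl ring carrying an amine or a carboxylic acid.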